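The source may report more compounds than this note shows. Statements on the series, on what has been measured and on what is new or still open speak of the compounds shown alone.

Working notes on the sulfonamide series.

The shared core, as in compound 1 `CCN(C/C=C/C#CC(C)(C)C)Cc1cccc(OCCN(C)S(=O)(=O)c2cccnc2)c1`, carries a varied aryl group on the sulfonyl sulfur. In a functional assay on HepG2 cells for inhibition of squalene monooxygenase (Homo sapiens) (on this read-out lower numbers stand for stronger inhibition and higher numbers for weaker inhibition), compound 1 gives 150 nM. Compound 2 `CCN(C/C=C/C#CC(C)(C)C)Cc1cccc(OCCN(C)S(=O)(=O)c2ccc(Br)s2)c1` gives 390 nM in this assay, and the step of a 2.6-fold higher number from compound 1 to compound 2 (0.41 log units; beyond the scatter) is the only one here that reaches beyond the scatter. Compound 3 `CCN(C/C=C/C#CC(C)(C)C)Cc1cccc(OCCN(C)S(=O)(=O)c2cc(Br)cs2)c1` gives 300 nM; the step of a 2.0-fold higher number from compound 1 to compound 3 (0.30 log units; within the scatter) stays within the scatter, as does the step of a 1.3-fold lower number from compound 2 to compound 3 (0.11 log units; within the scatter). Compound 3 thus stands with the second highest of the three numbers, its nearest neighbour compound 2 and its furthest compound 1, both gaps within the scatter.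

Compound 4 `CCN(C/C=C/C#CC(C)(C)C)Cc1cccc(OCCN(C)S(=O)(=O)c2cc(-c3ccsc3)cs2)c1` is not yet measured. It differs from compound 3 by thiophen-3-yl in place of bromo on an aromatic carbon. For the measured compounds named here, none of the three measured steps tests this kind of change: all of them exchange the whole aryl group on the sulfonyl sulfur, and no compound shows what a second ring attached to the thiophene does. Going by the values given here, the two thiophene variants that do exist, compound 2 and compound 3, sit within the scatter of each other, and even the one step beyond the scatter, from compound 1 to compound 2, is modest. The expectation is therefore a step of a 1.3-fold higher number from compound 3 to compound 4 (0.12 log units; within the scatter) that need not pass the scatter, in either direction. For compound 4 the estimated value in this assay is 400 nM, with a range from 130 nM to 1200 nM.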

Compound 4, half-maximal inhibitory concentration: 90 nM
Compound 4: the middle estimate sits 4.4-fold (0.65 log units) above what was measured; measured number below the stated range.
By their numbers in this assay, from the lowest: compounds 4, 1, 3 and 2 (each within the scatter of the next, the first and the last beyond it).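

For the compounds shown here, on the thiophene ring, at the aromatic carbon two ring bonds from the ring sulfur, thiophen-3-yl in place of bromo gives a 3.3-fold lower number from compound 3 to compound 4 (0.52 log units; beyond the scatter) in this assay, so this position accepts a second aromatic ring and the number moves beyond the scatter, which is the first reading of a change made on the thiophene itself rather than an exchange of the whole aryl group on the sulfonyl sulfur. Measured against the other aryl groups, 4-(thiophen-3-yl)thiophen-2-yl in place of 5-bromothiophen-2-yl gives a 4.3-fold lower number from compound 2 to compound 4 (0.64 log units; beyond the scatter), and in place of pyridin-3-yl it gives a 1.7-fold lower number from compound 1 to compound 4 (0.22 log units; within the scatter), so it separates from both bromothiophene variants but not from the pyridine. Nothing available on measured properties of these groups bears on this result.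

From the compounds shown here alone, whether the step belongs to thiophen-3-yl in particular or to any ring at this carbon remains open, and a phenyl ring, a simple methyl group, an amine or a carboxylic acid on the same carbon would begin to separate these readings. Also open, going by these compounds, is what thiophen-3-yl does on the carbon that bears bromo in compound 2.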